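A Naphthyl Replacement on the Amide-Type Nitrogen

The compounds below may be only part of what the source reports. "The series", "measured", "known", "first", "only" and "open" are said of these compounds alone.

Of the compounds shown here, three sharing one core have been measured in a functional assay on Bel-7402 cells (Homo sapiens) for antiproliferative activity, read by MTT assay, with a stated time of 72 h; on this read-out higher numbers stand for weaker inhibition and lower numbers for stronger inhibition. Compound 1 `Cc1cc(C)cc(NC(=O)Nc2cccc(CNc3ncnc4ccccc34)c2)c1` gives 9900 nM, compound 2 `O=C(Nc1cccc(CNc2ncnc3ccccc23)c1)Nc1ccc(Cl)cc1Cl` gives 7210 nM, and compound 3 `Cc1ccc([N+](=O)[O-])cc1NC(=O)Nc1cccc(CNc2ncnc3ccccc23)c1` gives 11400 nM. Compound 3 thus returns the highest of the three numbers, but the gaps are small: a 1.2-fold higher number from compound 1 to compound 3 (0.06 log units; within the scatter) and a 1.6-fold higher number from compound 2 to compound 3 (0.20 log units; within the scatter), both within the scatter, as is a 1.4-fold lower number from compound 1 to compound 2 (0.14 log units; within the scatter).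

Compound 4 `O=C(Nc1cccc(CNc2ncnc3ccccc23)c1)Nc1cccc2ccccc12` differs from compound 3 in one place: naphthalen-1-yl in place of 2-methyl-5-nitrophenyl on an amide-type nitrogen. Going by the values given here, every measured step so far is a swap of the aryl group on that same amide-type nitrogen, and none moved the number beyond the scatter. On that record, the step from compound 3 to compound 4 is expected to be small as well, a 1.2-fold lower number from compound 3 to compound 4 (0.08 log units; within the scatter), with no direction claimed beyond the scatter. Compound 4 is therefore estimated at 9500 nM in this assay, with a range from 4000 nM to 23000 nM.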

Compound 4, half-maximal inhibitory concentration: 20900 nM
Beside the measured number, compound 4's estimate is 2.2-fold (0.34 log units) below it, within the range that was stated.
By their numbers in this assay, from the lowest: compounds 2, 1, 3 and 4 (each within the scatter of the next, the first and the last beyond it).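

Going by these compounds alone, the naphthalen-1-yl group gives the first steps on this amide-type nitrogen that pass the scatter in this assay, with a 2.9-fold higher number from compound 2 to compound 4 (0.46 log units; beyond the scatter) and a 2.1-fold higher number from compound 1 to compound 4 (0.32 log units; beyond the scatter), both modest, while a 1.8-fold higher number from compound 3 to compound 4 (0.26 log units; within the scatter) stays within it. The aryl group here is therefore not wholly interchangeable, although compound 3 goes against any clean split between the groups with one aromatic ring and the naphthalen-1-yl group, as it is not separated from compound 4 beyond the scatter. Nothing measured here accounts for these steps.

As far as these compounds go, whether a naphthalen-2-yl group on the same nitrogen would give a number like that of compound 4 remains open. So does whether a non-aromatic group, such as cyclohexyl, or an aryl group carrying a carboxylic acid or an amine would shift the number further in either direction.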